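Trimethoxyphenyl series: dimethoxyphenyl replacing dichlorophenyl on the saturated ring carbon

A few compounds are considered here, and "the series" means these few. Any claim that something is new, unique, unknown or untested is made for them only; others in the source may bear on it.

Compound 1 `COc1cc(C2=NN(C(C)=O)C(c3c(Cl)cccc3Cl)O2)cc(OC)c1OC` gives -1.4% in a functional assay on BGC-823 cells (Homo sapiens) for antiproliferative activity, read by MTT assay, tested at 1 uM; a higher number here means a stronger effect of the compound at the concentration tested, a lower number a weaker effect. Compound 2 `COc1cc(C2=NN(C(C)=O)C(c3cc(Cl)cc(Cl)c3)O2)cc(OC)c1OC` gives 0% in this assay. Compound 3 `COc1cc(C(=O)N/N=C/c2ccccc2C(F)(F)F)cc(OC)c1OC` gives 22.1% in this assay.

Compound 2 stands second highest of the three numbers. Its nearest neighbour is compound 1, with the step of a number 1.4 percentage points higher from compound 1 to compound 2 (within the scatter). Its furthest neighbour is compound 3, whose value differs from that of compound 2 by more than the scatter; compound 3 also carries a different core, so the two values are set side by side without a single-point step between them.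

Compound 4 `COc1cc(C2=NN(C(C)=O)C(c3cccc(OC)c3OC)O2)cc(OC)c1OC` is the next member. It differs from compound 2 by 2,3-dimethoxyphenyl in place of 3,5-dichlorophenyl on a saturated ring carbon. Going by the values given here, only one measured step touches the group on the saturated ring carbon, the step from compound 1 to compound 2, and that step stayed within the scatter while moving chlorine atoms around the same ring. Among the compounds with values here, no measured step exchanges chlorine for methoxy on this ring, so there is no basis for expecting a step beyond the scatter in this assay, in either direction. Compound 4 is therefore expected to give 5%, within -10% to 25%. The step implied, a number 5 percentage points higher from compound 2 to compound 4 (within the scatter), is expected to stay within the scatter.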

Compound 4, a percentage reported as inhibition, at one concentration (the size of the read-out at that concentration, not a potency): 3.8%
Estimate against measurement, compound 4: 1.2 percentage points above; the range from low to high includes it.
By their numbers in this assay, from the lowest: compounds 1, 2 and 4 (each within the scatter of the next); then compound 3.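

Replacing 3,5-dichlorophenyl with 2,3-dimethoxyphenyl on the saturated ring carbon gives a number 3.8 percentage points higher from compound 2 to compound 4 (within the scatter) in this assay, and replacing 2,6-dichlorophenyl with the same group gives a number 5.2 percentage points higher from compound 1 to compound 4 (within the scatter). The position has now been probed with a different kind of substituent as well as with moved chlorine atoms, and on the shared core all three aryl groups give readings within the scatter of one another at the single concentration tested. No measured evidence bears on why these exchanges leave the reading so little changed.

On these data alone, whether an amine or a carboxylic acid on this aryl ring would give a step beyond the scatter remains open. So does the effect of replacing the aryl ring with a longer alkyl chain.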